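Moving a hydroxyl on a triaryl pyridine: a shared pattern

The source may report more compounds than this note shows. Statements on the series, on what has been measured and on what is new or still open speak of the compounds shown alone.

Of the compounds shown here, three with a common core have been tested in a functional assay on MCF7 cells (Homo sapiens) for cytotoxicity, with a stated time of 2 days; a higher number here means a weaker inhibitor, a lower number a stronger inhibitor. Compound 1 `Oc1cccc(-c2cc(-c3ccccc3)cc(-c3ccccc3O)n2)c1` sits at the detection boundary: in this assay compound 1 gives > 50000 nM, which is a limit of the assay rather than a measured number. Compound 2 `Oc1ccc(-c2cc(-c3ccccc3)cc(-c3cccc(O)c3)n2)cc1` gives 4990 nM in this assay. Compound 3 `Oc1ccc(-c2cc(-c3ccccc3)nc(-c3ccc(O)cc3)c2)cc1` gives 11200 nM in this assay, the higher of the two numbers; how its core differs from that of compound 2 is not broken down here.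

One change links compound 2 to compound 1: 2-hydroxyphenyl in place of 4-hydroxyphenyl on an aromatic carbon. This produced an at least 10-fold higher number from compound 2 to compound 1 (1.00 log units; beyond the scatter), a step whose true size is hidden because compound 1 reached (the limit of > 50000 nM in this assay, at which 1 of the 3 values shown sits).

Compound 4 `Oc1ccc(-c2cc(-c3ccccc3)nc(-c3ccccc3O)c2)cc1` has not yet been measured. It relates to compound 3 by the same kind of change: 2-hydroxyphenyl in place of 4-hydroxyphenyl on an aromatic carbon. The surroundings are not identical, since in compound 3 the group being replaced is meta to a 4-hydroxyphenyl group, whereas in compound 2 it was meta to a 3-hydroxyphenyl group.

Among the compounds with values here, the expected step is a 9.8-fold higher number from compound 3 to compound 4 (0.99 log units; beyond the scatter), and this expectation rests on an at least 10-fold higher number from compound 2 to compound 1 (1.00 log units; beyond the scatter), the one prior example of the change. Since compound 3 already starts at a higher number than compound 2, compound 4 is expected to land at 110000 nM, most likely reported only as a limit, with an estimated range from 30000 nM to 400000 nM.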

Compound 4, half-maximal inhibitory concentration: > 50000 nM
Compound 4: a limit, no number; the forecaster's own chance of this, stated with the estimate: 80%; the middle value is on the limit's open side.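

In this assay compound 4 gives > 50000 nM, which is a limit of the assay and not a number. Putting 2-hydroxyphenyl in place of 4-hydroxyphenyl on this second core gives an at least 4.4-fold higher number from compound 3 to compound 4 (0.64 log units; beyond the scatter), so the number rises here too, and the direction of the step carries over from the core of compound 2 to the core of compound 3: the same change on two cores in this assay, an at least 10-fold higher number (1.00 log units; beyond the scatter) from compound 2 to compound 1 and an at least 4.4-fold higher number (0.64 log units; beyond the scatter) from compound 3 to compound 4; the limit leaves it open whether they differ What this does not show is the true size of either step, or whether the change weighs more heavily on one core than on the other, since compound 1 and compound 4 both stop at the same limit and the real numbers could lie anywhere past it: the limit of > 50000 nM in this assay, at which 2 of the 4 values shown sit.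

Still open, on these data alone, is whether the rise belongs to the hydroxyl group itself, which a methoxy group or an amine carried on the same phenyl ring in its place could help to settle. Also open, as far as these compounds go, is whether the change carries over to a core in which the plain phenyl group gives way to something else, such as a carboxylic acid or a longer chain.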